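From pyrimidin-2-yl to oxan-4-yl on the carbonyl carbon

The source may hold more compounds than are shown below. What is called first, only, known or untested is meant among the compounds shown, and "the series" means these compounds.

In an ADME assay on microsomes from liver (Mus musculus) for pharmacokinetics, read by LC-MS, using NADPH, with stated times of 5 min, 15 min and 30 min, tested at 10 uM (on this read-out lower numbers stand for slow clearance and higher numbers for fast clearance), compound 2 `C[C@H](NC(=O)c1ncccn1)c1ccc(NC(=O)N2CC(c3ccc(N)nc3)C2)cc1` gives < 25 mL.min-1.g-1, which is a limit of the assay and not a number. Compound 1 `C[C@@H](c1ccc(NC(=O)N2CC(c3ccc(N)nc3)C2)cc1)N1Cc2ccccc2C1=O` gives < 25 mL.min-1.g-1, which is also a limit. Both measured compounds therefore stand at the same mark: the limit of < 25 mL.min-1.g-1 in this assay, at which 2 of the 2 values shown sit.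

Compound 3 `C[C@H](NC(=O)C1CCOCC1)c1ccc(NC(=O)N2CC(c3ccc(N)nc3)C2)cc1` carries oxan-4-yl in place of pyrimidin-2-yl on a carbonyl carbon.

Among the measured compounds shown here, only one measured step bears on this change, and it lies elsewhere on the molecule: a step that the two limits leave unreadable from compound 1 to compound 2. It offers no size to carry over, so no step beyond the scatter is expected in this assay, and no direction is expected either. The estimated change is a step that the limit leaves unreadable from compound 2 to compound 3.

The expected value for compound 3 is 20 mL.min-1.g-1, with an estimated range from 10 mL.min-1.g-1 to 40 mL.min-1.g-1.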

Compound 3, intrinsic clearance in microsomes: < 25 mL.min-1.g-1
Compound 3 ended at the assay's limit (the forecaster's own chance of this, stated with the estimate: 65%); the middle value does not contradict the limit.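

In this assay compound 3 gives < 25 mL.min-1.g-1, which is a limit of the assay and not a number. No step can be read among compound 1, compound 2 and compound 3, which all stand at one mark: the limit of < 25 mL.min-1.g-1 in this assay, at which 3 of the 3 values shown sit.

Going by these compounds, whether oxan-4-yl and pyrimidin-2-yl differ in clearance on the carbonyl carbon stays open.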